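Swapping a benzamido for an acetoxy: what remains?

The source may hold more compounds than are shown below. What is called first, only, known or untested is meant among the compounds shown, and "the series" means these compounds.

Three compounds share one core and differ only in the group on a saturated ring carbon of the six-membered non-aromatic ring. Compound 1 `O=C(OC1CCC(CN2CCN(c3cc(=O)c4cc(C(F)(F)F)cc([N+](=O)[O-])c4s3)CC2)CC1)c1cccs1` carries a ((thiophen-2-yl)carbonyl)oxy group there, compound 2 `O=C(OC1CCC(CN2CCN(c3cc(=O)c4cc(C(F)(F)F)cc([N+](=O)[O-])c4s3)CC2)CC1)c1ccncc1` a ((pyridin-4-yl)carbonyl)oxy group, and compound 3 `O=C(NC1CCC(CN2CCN(c3cc(=O)c4cc(C(F)(F)F)cc([N+](=O)[O-])c4s3)CC2)CC1)c1ccccc1` a benzamido group. In an ADME assay on cells (Hepatocyte, Mus musculus) for metabolic stability, with a stated time of 30 min (a lower number here means that less of the compound is left, a higher number that more of the compound is left), compound 1 gives 1.8% and compound 2 gives 1.4%; the two lie close, as the step of a number 0.4 percentage points lower from compound 1 to compound 2 (within the scatter) shows. Compound 3, in contrast, gives 90.6%, the highest of the three numbers, far beyond both others: the steps of a number 88.8 percentage points higher from compound 1 to compound 3 (beyond the scatter) and a number 89.2 percentage points higher from compound 2 to compound 3 (beyond the scatter) are both large.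

Compound 4 `CC(=O)OC1CCC(CN2CCN(c3cc(=O)c4cc(C(F)(F)F)cc([N+](=O)[O-])c4s3)CC2)CC1` is not yet measured. It is related to compound 3 by the change (acetoxy in place of benzamido on a saturated ring carbon). This move runs opposite to the two large steps just named: there, replacing an oxygen-linked carbonyl group by a benzamido group raised the number enormously; here, the benzamido group departs and an oxygen-linked carbonyl group, the acetoxy, enters. A large drop in this assay is therefore expected, of about a number 84.6 percentage points lower from compound 3 to compound 4 (beyond the scatter). For compound 4 the estimated value is 6%, with a likely range from 0.5% to 30%.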

Compound 4, percent of the compound remaining: 0%
Compound 4: middle estimate off by 6 percentage points, on the high side, outside the stated range (below it).
By their numbers in this assay, from the lowest: compounds 4, 2 and 1 (each within the scatter of the next); then compound 3.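

In this assay, the step of a number 90.6 percentage points lower from compound 3 to compound 4 (beyond the scatter) shows that a large fall at this saturated ring carbon does not require an aromatic ring on the oxygen-linked carbonyl, as the acetoxy group has no ring and only 4 heavy atoms. The steps of a number 1.4 percentage points lower from compound 2 to compound 4 (within the scatter) and a number 1.8 percentage points lower from compound 1 to compound 4 (within the scatter) place compound 4 with compounds 1 and 2, so methyl, pyridin-4-yl and thiophen-2-yl on the carbonyl carbon cannot be told apart in this assay, and among these four compounds only compound 3, with its benzamido group, stands apart. No accompanying measurement explains this split between the oxygen-linked groups and the benzamido group.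

The benzamido group differs from all three oxygen-linked groups both in the atom joining its carbonyl to the ring and in what that carbonyl carries, so the compounds shown do not separate these two changes. An acetamido group, which keeps the methyl with a nitrogen link, and a benzoyloxy group, which keeps the benzene ring with an oxygen link, would each test one change alone, while a simple amine on the same carbon would show the number with no carbonyl there at all.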